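Same atoms, rejoined rings: expectations for compound 4

A few compounds are considered here, and "the series" means these few. Any claim that something is new, unique, unknown or untested is made for them only; others in the source may bear on it.

In a physicochemical assay for lipophilicity, using the shake flask method, measured as octanol-water partition, at pH 7.4 (on this read-out higher numbers stand for higher lipophilicity and lower numbers for lower lipophilicity), compound 3 `CC(=O)N[C@@H]1CCC[C@H](C(=O)Nc2cc(-c3cnn4c3CCCCC4)c(Cl)cn2)C1` stands highest at 3.6, ahead of compound 1 `CC(=O)N[C@@H]1CCC[C@H](C(=O)Nc2cc(-c3cnn4c3CCCC4)c(Cl)cn2)C1` at 3.2 and compound 2 `CC(=O)N[C@@H]1CCC[C@H](C(=O)Nc2cc(-c3nnn4ccccc34)c(Cl)cn2)C1` at 2. Compound 4 `CC(=O)N[C@@H]1CCC[C@H](C(=O)Nc2cc(-c3cnc4n3CC(C)(C)C4)c(Cl)cn2)C1` has the same atoms as compound 3, joined differently: a group of 10 heavy atoms (8 carbon, 2 nitrogen; one five-membered non-aromatic ring with 1 hetero atom, one five-membered aromatic ring with 2 hetero atoms) in place of a group of 10 heavy atoms (8 carbon, 2 nitrogen; one five-membered aromatic ring with 2 hetero atoms, one seven-membered non-aromatic ring with 1 hetero atom), on an aromatic carbon. Among the compounds with values here, no measured compound carries the entering group, so the precedents are indirect. The seven-membered non-aromatic ring accompanied a number 0.40 log units higher from compound 1 to compound 3 (beyond the scatter), a modest step. Changing both rings gave a number 1.20 log units lower from compound 1 to compound 2 (beyond the scatter), a large step, and this shows how far a ring change can move the number in this short series. A moderate fall is therefore expected, with an estimated a number 0.70 log units lower from compound 3 to compound 4 (beyond the scatter). The estimate for compound 4 is 2.9, with an expected range of 2.3 to 3.4.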

Compound 4, distribution coefficient: 3.6
Estimate against measurement, compound 4: 0.70 log units below, outside the stated range (above it).
By their numbers in this assay, from the lowest: compound 2; then compound 1; then compounds 3 and 4 (each within the scatter of the next).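

On this aromatic carbon, opposite the ring nitrogen, the same atoms rejoined as a five-membered non-aromatic ring and a five-membered aromatic ring give, in this assay, no change at the digits printed from compound 3 to compound 4 (within the scatter). The wider steps, a number 0.40 log units higher from compound 1 to compound 4 (beyond the scatter) and a number 1.60 log units higher from compound 2 to compound 4 (beyond the scatter), equal in size those printed for compound 3, so here the two ring arrangements are not separated by this read-out. No supporting data bear on why this is so.

Open, from the compounds shown here alone, is whether an amine or a carboxylic acid on the five-membered non-aromatic ring would keep the number there. A longer chain in place of these fused rings is equally unresolved.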